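A triazole replaces the ring of compound 3

A few compounds are considered here, and "the series" means these few. Any claim that something is new, unique, unknown or untested is made for them only; others in the source may bear on it.

Measured in a physicochemical assay for metabolic stability, read by HPLC and mass spectrometry, in phosphate buffer, at 37 degrees C, at pH 7.4; a lower number here means that the compound disappears faster, a higher number that the compound lasts longer:
- compound 1 `CC(C)(O/N=C(\C(=O)N[C@@H]1C(=O)N(S(=O)(=O)O)[C@@H]1CNC(=O)CN)c1csc(N)n1)C(=O)O`: 149 h
- compound 2 `CC(C)(O/N=C(\C(=O)N[C@@H]1C(=O)N(S(=O)(=O)O)[C@@H]1CN1CCCC1=O)c1csc(N)n1)C(=O)O`: > 1000 h (a limit)
- compound 3 `CC(C)(O/N=C(\C(=O)N[C@@H]1C(=O)N(S(=O)(=O)O)[C@@H]1CN1CCNC1=O)c1csc(N)n1)C(=O)O`: > 1000 h (a limit)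

Compound 3 stands at the limit of > 1000 h in this assay, at which 2 of the 3 values shown sit. Going by these compounds, that is a limit and not a number, so its true half-life is unknown. The comparison with its closest relative gives a step that the two limits leave unreadable from compound 2 to compound 3.

The next compound, compound 4 `CC(C)(O/N=C(\C(=O)N[C@@H]1C(=O)N(S(=O)(=O)O)[C@@H]1Cn1cncn1)c1csc(N)n1)C(=O)O`, keeps the shared core and changes one group: 1H-1,2,4-triazol-1-yl in place of 2-oxoimidazolidin-1-yl on a saturated chain carbon bound to a saturated ring carbon. In words, 1H-1,2,4-triazol-1-yl takes the place of 2-oxoimidazolidin-1-yl.

Going by the values given here, two measured steps bear on this: an at least 6.7-fold higher number from compound 1 to compound 2 (0.82 log units; beyond the scatter) and an at least 6.7-fold higher number from compound 1 to compound 3 (0.82 log units; beyond the scatter). In both, a ring replaces the open ((aminomethyl)carbonyl)amino group, and compound 4 also carries a ring there. However, neither step brings in an aromatic ring, so the guidance is limited.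

A small step is expected, and if it can be read at all, it is expected to point downward. The estimate means an at least 1.4-fold lower number from compound 3 to compound 4 (0.15 log units; that floor lies within the scatter). Compound 4 is expected to show a half-life of 700 h, within an estimated range of 200 h to 2500 h.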

Compound 4, half-life: 233 h
Estimate against measurement, compound 4: 3.0-fold (0.48 log units) above, within the range that was stated.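

In this assay, not every ring at this place, on a saturated chain carbon bound to a saturated ring carbon, behaves alike: the aromatic 1H-1,2,4-triazol-1-yl gives an at least 4.2-fold lower number from compound 3 to compound 4 (0.63 log units; beyond the scatter) and an at least 4.2-fold lower number from compound 2 to compound 4 (0.63 log units; beyond the scatter). Compound 2 and compound 3 each stand at a limit and not a number, so these two steps give only a floor for the drop: the limit of > 1000 h in this assay, at which 2 of the 4 values shown sit. The triazole also cannot be told apart from the open ((aminomethyl)carbonyl)amino group, with a 1.6-fold higher number from compound 1 to compound 4 (0.19 log units; within the scatter), so the gain seen with the two saturated rings does not carry over to this aromatic ring.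

Going by these compounds, the step between compound 2 and compound 3 cannot be read, so which of those two saturated rings gives the longer half-life stays open. On these data alone, how a pyrazole ring or a simple amine at this place would behave also stays open.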